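The compounds below may be only part of what the source reports. "The series", "measured", "known", "first", "only" and "open" are said of these compounds alone.

Compound 2 `O=C(/C=C/c1ccc2c(c1)B(O)OC2)c1ccccc1F` in an ADME assay on L929 cells (Mus musculus) for cytotoxicity, read by resazurin assay, with a stated time of 72 h (on this read-out lower numbers stand for stronger inhibition and higher numbers for weaker inhibition), reports only a limit of the assay, > 10 ug/mL. Compound 1 `Cc1cccc(C(=O)/C=C/c2ccc3c(c2)B(O)OC3)c1` gives 8.56 ug/mL in this assay; the step of an at least 1.1-fold higher number from compound 1 to compound 2 (0.06 log units; that floor lies within the scatter) runs into (the limit of > 10 ug/mL in this assay, at which 1 of the 2 values shown sits), so its true size is not known. Compound 3 `Cn1cccc1C(=O)/C=C/c1ccc2c(c1)B(O)OC2` is not yet measured; it differs from compound 2 by 1-methyl-1H-pyrrol-2-yl in place of 2-fluorophenyl on a carbonyl carbon. Among the compounds with values here, only the step from compound 1 to compound 2 concerns the group on the carbonyl carbon, and it ends at the limit, so no direction beyond the scatter is expected for compound 3 in this assay. Compound 3 is therefore expected near 10 ug/mL, within 5 ug/mL to 20 ug/mL. The step expected is a number no higher from compound 2 to compound 3 (the limit leaves the size open).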

Compound 3, half-maximal inhibitory concentration: > 10 ug/mL
Compound 3: no number, only a limit (the forecaster's own chance of this, stated with the estimate: 55%); the middle value lies on the limit itself.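

In this assay, 1-methyl-1H-pyrrol-2-yl in place of 3-methylphenyl on a carbonyl carbon gives an at least 1.1-fold higher number from compound 1 to compound 3 (0.06 log units; that floor lies within the scatter). The step between the two limit compounds, compound 2 and compound 3, cannot be read. A five-membered aromatic ring with a hetero atom at this position therefore ends at the limit, as 2-fluorophenyl does, leaving two different rings here without a readable number: the limit of > 10 ug/mL in this assay, at which 2 of the 3 values shown sit.

From the compounds shown here alone, how far compound 2 and compound 3 lie past the limit remains open. Also open, going by these compounds, is whether an aminophenyl or a carboxyphenyl group on the carbonyl carbon would give a readable number in this assay.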